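From compound 1 to compound 3: fluoro for chloro

A few compounds are considered here, and "the series" means these few. Any claim that something is new, unique, unknown or untested is made for them only; others in the source may bear on it.

In a functional assay on MGC-803 cells (Homo sapiens) for antiproliferative activity, read by MTT assay, with a stated time of 48 h (on this read-out higher numbers stand for an effect only at larger amounts of compound and lower numbers for an effect already at smaller amounts), compound 1 (`CC1=NN(C(=O)CCl)C(c2cc(Cl)ccc2O)C1`) gives 12300 nM, the higher of the two numbers available. Compound 2 (`CC1=NN(C(=O)CBr)C(c2ccccc2O)C1`) gives 3650 nM, a gap beyond the usual scatter, which leaves compound 1 as the less potent of the pair. The unmeasured compound 3 (`CC1=NN(C(=O)CCl)C(c2cc(F)ccc2O)C1`) keeps the core of compound 1 and changes one substituent: fluoro in place of chloro on an aromatic carbon, para to a hydroxy group. Going by the values given here, no measured pair isolates a change at this place, so the data offer no direct precedent. With only this one substituent exchanged, no step beyond the scatter is expected in this assay, and neither direction is favoured. The expected step is a 1.0-fold lower number from compound 1 to compound 3 (0.01 log units; within the scatter). Compound 3 is estimated at 12000 nM, with an expected range of 5000 nM to 28000 nM.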

Compound 3, half-maximal effective concentration: 6870 nM
Estimate against measurement, compound 3: 1.7-fold (0.24 log units) above; measured number inside the range.
By their numbers in this assay, from the lowest: compounds 2, 3 and 1 (each within the scatter of the next, the first and the last beyond it).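

In this assay, going by these compounds alone, fluoro in place of chloro on an aromatic carbon, para to a hydroxy group, gives a 1.8-fold lower number from compound 1 to compound 3 (0.25 log units; within the scatter) and is the first measured pair that isolates a change at this position. On this read-out the two halogens at this place are not told apart, so the position accepts the exchange without a step beyond the scatter. No available measurement bears on why the two substituents read alike.

On these data alone, how this position reads with a group other than a halogen, such as a methoxy group, an amine or a carboxylic acid, remains open. Also open, as far as these compounds go, is whether the same exchange reads alike with bromo in place of the other chloro of compound 1.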